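The source may hold more compounds than are shown below. What is called first, only, known or untested is meant among the compounds shown, and "the series" means these compounds.

Working notes on the series. The shared core is kept constant throughout; the compounds differ only in the aromatic group carried on it. Compound 1 `CCCS(=O)(=O)Nc1ccc(F)c(C(=O)c2n[nH]c3ncc(-c4cccc(C)c4)cc23)c1F` in an assay for binding affinity to dual specificity mitogen-activated protein kinase kinase 4 (Homo sapiens), read by KINOMEscan, tested at 100 nM (a higher number here means a weaker effect of the compound at the concentration tested, a lower number a stronger effect), gives 15%. Compound 2 `CCCS(=O)(=O)Nc1ccc(F)c(C(=O)c2n[nH]c3ncc(-c4ccc(OC)cc4)cc23)c1F` gives 4.2% in this assay, so that a number 10.8 percentage points lower from compound 1 to compound 2 (beyond the scatter). Compound 3 `CCCS(=O)(=O)Nc1ccc(F)c(C(=O)c2n[nH]c3ncc(-c4ccccc4N)cc23)c1F` gives 23% in this assay. Compound 3 stands highest of the three numbers: against compound 1 the step is a number 8 percentage points higher from compound 1 to compound 3 (within the scatter), while against compound 2 the step is a number 18.8 percentage points higher from compound 2 to compound 3 (beyond the scatter).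

Compound 4 `CCCS(=O)(=O)Nc1ccc(F)c(C(=O)c2n[nH]c3ncc(-c4ccc(Cl)c(Cl)c4)cc23)c1F` has not yet been measured in this assay. It differs from compound 3 by 3,4-dichlorophenyl in place of 2-aminophenyl on an aromatic carbon. Two measured steps end at compound 3 and so bear on this change: a number 8 percentage points higher from compound 1 to compound 3 (within the scatter) and a number 18.8 percentage points higher from compound 2 to compound 3 (beyond the scatter). In both, compound 3 with its 2-aminophenyl holds the higher number, once within and once beyond the scatter. Within the data shown here, the 3,4-dichlorophenyl has no measured counterpart, so the direction rests only on compound 3 standing at 23%, the top of the range so far. For compound 4 the expected step is a number 11 percentage points lower from compound 3 to compound 4 (beyond the scatter), a modest downward move toward the middle of the measured values. Compound 4 is therefore estimated at 12%, with a range from 3% to 30%.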

Compound 4, a percentage reported as activity, at one concentration (the size of the read-out at that concentration, not a potency): 45%
Beside the measured number, compound 4's estimate is 33 percentage points below it, and the stated range ends below it.
By their numbers in this assay, from the lowest: compound 2; then compounds 1 and 3 (each within the scatter of the next); then compound 4.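

Among these compounds, compound 4 is the first group at this position to take the read-out in this assay clearly above every other compound: a number 22 percentage points higher from compound 3 to compound 4 (beyond the scatter), a number 30 percentage points higher from compound 1 to compound 4 (beyond the scatter), and a number 40.8 percentage points higher from compound 2 to compound 4 (beyond the scatter). The last of these steps is larger than a number 18.8 percentage points higher from compound 2 to compound 3 (beyond the scatter), so the aromatic group on this carbon of the shared core can change the number at the tested concentration considerably more than the first three compounds showed, and 3,4-dichlorophenyl gives the weakest effect of the four. No measurement shown here accounts for this rise, and the change from 2-aminophenyl also removes a hydrogen-bond donor and acceptor without showing that their loss matters.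

Among the compounds shown here, compound 4 is the only compound here with chlorine and the only one with two substituents on the aromatic group, so the two features cannot be separated. As far as these compounds go, whether the higher number follows from chlorine itself, from its placement, or from the double substitution remains open, and a plain phenyl or a phenyl carrying one chlorine would bear on that question.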